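From propanoyloxy to bromo: a step without a direct precedent

A few compounds are considered here, and "the series" means these few. Any claim that something is new, unique, unknown or untested is made for them only; others in the source may bear on it.

In a functional assay on DLD-1 cells (Homo sapiens) for cytotoxicity, with a stated time of 48 h (on this read-out lower numbers stand for stronger inhibition and higher numbers for weaker inhibition), compound 1 `CCCCOc1ccc2oc(/C=C/[S+](C)[O-])cc(=O)c2c1` gives 4800 nM and compound 2 `CCC(=O)Oc1ccc2oc(/C=C/[S+](C)[O-])cc(=O)c2c1` gives 9000 nM so far, and these two values lie within the scatter of each other. Compound 2 therefore cannot be ranked against compound 1 on the present numbers.

Compound 3 `C[S+]([O-])/C=C/c1cc(=O)c2cc(Br)ccc2o1` has no number yet. It keeps the shared core of compound 2 and differs in one place, with bromo in place of propanoyloxy on an aromatic carbon as the counted change. In short, this is bromo in place of propanoyloxy on an aromatic carbon.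

Within the data shown here, only one measured step bears on this. The swap of butyl for propanoyl on an oxygen on an aromatic ring, a 1.9-fold higher number from compound 1 to compound 2 (0.27 log units; within the scatter) as measured, stayed within the scatter. That step involves no bromo group, so the data offer only weak and indirect guidance.

No step beyond the scatter is expected in this assay and no firm direction can be given. An estimated 1.4-fold lower number from compound 2 to compound 3 (0.14 log units; within the scatter) is the expected outcome on these grounds. For compound 3 the expected value is 6500 nM with an estimated range from 2500 nM to 17000 nM on this read-out.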

Compound 3, half-maximal inhibitory concentration: 4500 nM
Estimate against measurement, compound 3: 1.4-fold (0.16 log units) above; the range from low to high includes it.
By their numbers in this assay, from the lowest: compounds 3, 1 and 2 (each within the scatter of the next).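

In this assay, bromo in place of propanoyloxy gives a 2.0-fold lower number from compound 2 to compound 3 (0.30 log units; within the scatter), and bromo in place of butoxy gives a 1.1-fold lower number from compound 1 to compound 3 (0.03 log units; within the scatter). Compounds 1 and 2 both carry an oxygen on this aromatic carbon, so they could not show whether that oxygen matters; compound 3 has none there, and with a single bromine atom in place of the five heavy atoms and two hydrogen-bond acceptors of propanoyloxy, it still stays within the scatter of both. For these three compounds, then, neither the oxygen attachment nor the larger group is needed to keep the number in this range, and no measurement available here explains that result.

As far as these compounds go, all three compounds lie within the scatter of one another, so it remains open whether any group on this aromatic carbon can produce a step beyond the scatter, and a primary amine, a carboxylic acid or a longer alkyl ether chain such as octyloxy would test that. The compounds shown also leave open whether this tolerance holds when the rest of the shared core is changed.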